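Fluoro in place of hydrogen on compound 2

The source may hold more compounds than are shown below. What is called first, only, known or untested is meant among the compounds shown, and "the series" means these compounds.

Two measured compounds frame this series in a functional assay on HL-60 cells (Homo sapiens) for inhibition, read by MTT assay, with a stated time of 48 h, tested at 10 uM (a higher number here means more inhibition of growth at the concentration tested, a lower number less inhibition of growth), and differ in more than one place. Compound 1 (`Cc1cc(=O)c2c(O)c(CN3CCC(Cc4ccccc4)CC3)c(O)c([C@H]3CCN(C)C[C@H]3O)c2o1`) gives 28% and compound 2 (`CN1CC[C@H](c2c(O)cc(O)c3c(=O)cc(/C=C/c4ccccc4)oc23)[C@H](O)C1`) gives 91% on the same read-out. Compound 2 holds the higher of the two numbers, and the gap between them lies beyond the usual scatter. That gap cannot be assigned to any single structural change.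

Compound 3 (`CN1CC[C@H](c2c(O)cc(O)c3c(=O)cc(/C=C/c4ccccc4F)oc23)[C@H](O)C1`) departs from compound 2 by one change: fluoro in place of hydrogen on an aromatic carbon, which turns phenyl into 2-fluorophenyl, ortho to a large group. For the measured compounds named here, no measured pair covers this change, so the expectation is loose. With compound 2 at 91% little room remains upward. The estimated a number 4 percentage points lower from compound 2 to compound 3 (within the scatter) is small, slightly downward and within the scatter. Compound 3 is expected to give 87% (range 68% to 98%).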

Compound 3, percent growth inhibition at one concentration: 62%
Estimate against measurement, compound 3: 25 percentage points above, outside the stated range (below it).
By their numbers in this assay, from the lowest: compound 1; then compound 3; then compound 2.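

In this assay, for the compounds shown here, fluoro in place of hydrogen on the phenyl of the 2-phenylethenyl arm gives a number 29 percentage points lower from compound 2 to compound 3 (beyond the scatter), the only step that can be read at a single place. This aromatic carbon, ortho to a large group, is therefore not indifferent to substitution: adding one fluorine atom there moves the read-out downward, beyond the scatter. No measurement among the data accounts for this fall.

Going by these compounds, it remains open whether the fall belongs to fluoro itself or to this carbon, since no other group stands here and fluoro stands on no other carbon of this ring. A chloro or methoxy group on the same carbon would separate the two readings, as would fluoro elsewhere on the ring.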